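Selenium in place of sulfur on a bis-amide core

The source may report more compounds than this note shows. Statements on the series, on what has been measured and on what is new or still open speak of the compounds shown alone.

Compound 1, `C[Se]/C(=N\C(=O)c1ccc([N+](=O)[O-])cc1)NC(=O)c1ccc([N+](=O)[O-])cc1`: in a functional assay on PC-3 cells (Homo sapiens) for cytotoxicity, read by MTT assay (on this read-out lower numbers stand for stronger inhibition and higher numbers for weaker inhibition), compound 1 gives > 10000 nM, which is a limit of the assay and not a number.
Compound 2, `CS/C(=N\C(=O)c1ccc(C)cc1)NC(=O)c1ccc(C)cc1`: in this assay compound 2 gives > 10000 nM, again a limit rather than a number.

Among the compounds with values here, compound 2 therefore stands nowhere on a scale of measured numbers; its result is only a limit, and the one further value shown is a limit as well. Every value shown sits at the limit of > 10000 nM in this assay, at which 2 of the 2 values shown sit. Compound 3, `C[Se]/C(=N\C(=O)c1ccc(C)cc1)NC(=O)c1ccc(C)cc1`, has yet to be measured in this assay. Compared with compound 2 it carries a group of 2 heavy atoms (1 carbon, 1 selenium; no ring) in place of a group of 2 heavy atoms (1 carbon, 1 sulfur; no ring), on a carbon with a double bond to nitrogen. Within the data shown here, no step between two measured compounds is available that would show how this exchange acts in this assay, so the expectation has to rest on the fact that both measured compounds reach only a limit, and that compound 1 already carries the selenium group. The step expected here is a step that the limit leaves unreadable from compound 2 to compound 3, that is, nothing beyond the usual scatter. Compound 3 is thus expected to give about 15000 nM, with a range from 5000 nM to 50000 nM, and most probably only a limit will be reported for compound 3.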

Compound 3, half-maximal inhibitory concentration: 1850 nM
Compound 3: the middle estimate sits 8.1-fold (0.91 log units) above what was measured, and the stated range ends above it.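

In this assay, within the data shown here, replacing methylsulfanyl with its selenium counterpart on the carbon with a double bond to nitrogen gives an at least 5.4-fold lower number from compound 2 to compound 3 (0.73 log units; beyond the scatter), the first readable step for this exchange at this position. This shows that the position is not indifferent to the change, at least with the shared core of these two compounds: compound 3 is the only compound shown with a true number, 1850 nM. The full size of the step stays unknown, and only its minimum can be stated, because compound 2 gives a limit and not a number: the limit of > 10000 nM in this assay, at which 2 of the 3 values shown sit.

Compound 1 also carries the selenium group, yet it gives > 10000 nM, a limit of the assay, and it differs from compound 3 in more than one place, so the two do not form a clean step and the gain cannot be assumed to hold with other groups on the core. It also remains open whether a longer chain on the selenium, such as an ethyl group, or an amine on the same carbon would keep this activity, and the compounds shown give no explanation for the effect of the exchange.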